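A few compounds are considered here, and "the series" means these few. Any claim that something is new, unique, unknown or untested is made for them only; others in the source may bear on it.

Three compounds have so far been measured in an ADME assay on HEK-293T cells (Homo sapiens) for cytotoxicity, read by MTT assay, with a stated time of 24 h; a lower number here means that less compound is tolerated, a higher number that more compound is tolerated:

compound 1, `Cc1ccc(-c2nn(-c3ccccc3)cc2-c2nc3ccccc3n2C(=O)c2ccccc2)cc1`, gives 204000 nM
compound 2, `Cc1ccc(-c2nn(-c3ccccc3)cc2-c2nc3ccccc3n2C(=O)c2cccc(C)c2)cc1`, gives 195000 nM
compound 3, `Cc1cccc(C(=O)n2c(-c3cn(-c4ccccc4)nc3-c3ccc(F)cc3)nc3ccccc32)c1`, gives 148000 nM

Compound 2 and compound 1 differ in one place, (hydrogen in place of methyl on an aromatic carbon), and this change made a step of a 1.0-fold higher number from compound 2 to compound 1 (0.02 log units; within the scatter) in this assay.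

Compound 4, `O=C(c1ccccc1)n1c(-c2cn(-c3ccccc3)nc2-c2ccc(F)cc2)nc2ccccc21`, has not yet been measured. It is related to compound 3 by hydrogen in place of methyl on an aromatic carbon. The cores on which the two changes are made differ from each other, and that difference is fluoro in place of methyl on an aromatic carbon; in this assay it came with a 1.3-fold lower number from compound 2 to compound 3 (0.12 log units; within the scatter). The change from compound 2 to compound 1 and the change from compound 3 to compound 4 have the same description of their place, so they can be taken as the same change made on two slightly different cores.

Since the earlier instance of this change, a 1.0-fold higher number from compound 2 to compound 1 (0.02 log units; within the scatter), stayed well within the usual scatter, compound 4 is expected to show a step of a 1.0-fold higher number from compound 3 to compound 4 (0.01 log units; within the scatter) in this assay, resting on that single earlier step and on the value of compound 3, 148000 nM. Going by the values given here, with only one earlier example of the change, the expectation carries the full width of the usual scatter.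

On this basis compound 4 is estimated to give 150000 nM in this assay, with an expected range from 85000 nM to 260000 nM.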

Compound 4, half-maximal cytotoxic concentration: 180000 nM
Compound 4: the middle estimate sits 1.2-fold (0.08 log units) below what was measured, within the range that was stated.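

Taking the methyl off the 3-methylphenyl group to leave a plain phenyl gave a 1.2-fold higher number from compound 3 to compound 4 (0.09 log units; within the scatter) in this assay, and this step agrees with the earlier instance of the same change: the same change on two cores in this assay, a 1.0-fold higher number (0.02 log units; within the scatter) from compound 2 to compound 1 and a 1.2-fold higher number (0.09 log units; within the scatter) from compound 3 to compound 4, 1.2-fold (0.07 log units) apart, within the scatter of two such steps

The second change in this set of four compounds, fluoro in place of methyl on an aromatic carbon, gave a 1.1-fold lower number from compound 1 to compound 4 (0.05 log units; within the scatter), and it also agrees with its earlier instance: the same change on two cores in this assay, a 1.3-fold lower number (0.12 log units; within the scatter) from compound 2 to compound 3 and a 1.1-fold lower number (0.05 log units; within the scatter) from compound 1 to compound 4, 1.2-fold (0.07 log units) apart, within the scatter of two such steps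

Going by these compounds alone, both changes therefore carried from one core to the other without a visible difference, but every step here is small enough to lie within the scatter, so this shows only that each change did little on these two closely related cores, not that a change with a large effect would carry over in the same way, nor that the agreement would hold on cores further from these.

The compounds shown vary only by a hydrogen, a methyl or a fluoro at these two places, so it stays open whether an amine, a carboxylic acid or a longer chain there would move the number in this assay beyond the scatter. Whether such a larger step would then repeat from one core to another is open as well.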